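This account rests on a few compounds, and the source may have more. Where it says the series, first, only, none or still open, it means among the compounds named here.

Of the compounds shown here, three sharing one core have been tested in a functional assay on MDA-MB-231 cells (Homo sapiens) for cytotoxicity, read by MTT assay, with a stated time of 48 h; a lower number here means a stronger inhibitor, a higher number a weaker inhibitor. Compound 1 `CC(=O)c1c(O)ccc2oc(-c3ccccc3)nc12` carries an acetyl group and lacks any chloro or methyl substituent; in this assay compound 1 reaches only the limit > 30000 nM, so no number is known for it. Compound 2 `O=Cc1c(O)ccc2oc(-c3ccccc3Cl)nc12` carries a formyl group and a chloro substituent, and in this assay compound 2 gives 5660 nM. Compound 3 `Cc1ccccc1-c1nc2c(C=O)c(O)ccc2o1` has a methyl in place of that chloro, and in this assay compound 3 gives 5360 nM. The step of a 1.1-fold lower number from compound 2 to compound 3 (0.02 log units; within the scatter) stays within the scatter, so compound 2 and compound 3 cannot be told apart on these numbers; compound 3 thus stands beside compound 2 as one of the two measured values, while compound 1 is known only as a limit.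

Compound 4 `CC(=O)c1c(O)ccc2oc(-c3ccccc3C)nc12` is compound 3 with methyl in place of hydrogen on a carbonyl carbon. Among the measured compounds shown here, no measured step follows exactly this change: compound 1 differs from compound 3 in two places, the acetyl group and the missing methyl, so its value can only be set side by side. In this assay compound 1 gave only a limit (the limit of > 30000 nM in this assay, at which 1 of the 3 values shown sits). Compound 3 gives a number. The step of a 1.1-fold lower number from compound 2 to compound 3 (0.02 log units; within the scatter) concerns a substituent on the aromatic ring, not the carbonyl, and says little here. Compound 4 is therefore expected to give a higher number than compound 3, by about a 4.7-fold higher number from compound 3 to compound 4 (0.67 log units; beyond the scatter), with a real chance that this assay again reports only a limit. The estimate for compound 4 is 25000 nM, expected between 8000 nM and 60000 nM.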

Compound 4, half-maximal inhibitory concentration: 30100 nM
Beside the measured number, compound 4's estimate is 1.2-fold (0.08 log units) below it; the range from low to high includes it.
By their numbers in this assay, from the lowest: compounds 3 and 2 (each within the scatter of the next); then compound 4.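

In this assay, methyl in place of hydrogen on a carbonyl carbon, the change from formyl to acetyl, gives a 5.6-fold higher number from compound 3 to compound 4 (0.75 log units; beyond the scatter). Among the compounds shown here, the only earlier readable step, methyl in place of chloro on an aromatic carbon, stayed within the scatter, so this carbonyl carbon is the first place in these compounds where a single change moves the number beyond it, towards a weaker inhibitor. The step from compound 1 to compound 4 cannot be read because compound 1 is known only as a limit: the limit of > 30000 nM in this assay, at which 1 of the 4 values shown sits.

Still open, as far as these compounds go, is how a carboxylic acid, an amide or a longer chain such as propanoyl would read in place of the formyl. Also open, from the compounds shown here alone, is whether formyl to acetyl gives a step of similar size with chloro in place of the methyl.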